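The source may hold more compounds than are shown below. What is called first, only, known or untested is meant among the compounds shown, and "the series" means these compounds.

Measured so far in a functional assay for inhibition, with Rattus norvegicus as the target; a higher number here means a weaker inhibitor, a lower number a stronger inhibitor:
compound 1, `CC(C)(CO)/N=c1\c(O)c(O)\c1=N/Cc1ccc(C#N)cc1`, 21300 nM
compound 2, `CCC(C)(C)/N=c1\c(O)c(O)\c1=N/Cc1ccc(F)cc1Cl`, 1500 nM
compound 3, `Cc1cc(Cl)cc(Cl)c1C/N=c1\c(O)c(O)\c1=N/C(C)(C)C`, 220 nM

Of these three, compound 1 gives the highest number and is the weakest inhibitor here: compound 2 lies well beyond the usual scatter below it, and compound 3 further still. Compound 4, `CC[C@@H](C)/N=c1\c(O)c(O)\c1=N/Cc1ccc(C#N)cc1`, has not yet been measured. Going by the values given here, it keeps the rest of compound 1 unchanged; the one change is sec-butyl in place of 1-(hydroxymethyl)-1-methylethyl on a double-bonded nitrogen. Compounds 2 and 3 also carry groups made only of carbon on the double-bonded nitrogen, yet they differ from compound 1 elsewhere too, so no single-change comparison exists. In this assay a moderate drop in the number is expected, a 4.3-fold lower number from compound 1 to compound 4 (0.63 log units; beyond the scatter). Compound 4 is therefore expected to give about 5000 nM, within a range from 1500 nM to 16000 nM.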

Compound 4, half-maximal inhibitory concentration: 4000 nM
Compound 4: middle estimate off by 1.3-fold (0.10 log units), on the high side; the measured number falls inside the stated range.
By their numbers in this assay, from the lowest: compound 3; then compound 2; then compound 4; then compound 1.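

Going by these compounds alone, this is the first comparison here in which only one group changes: with the rest of compound 1 kept, sec-butyl in place of 1-(hydroxymethyl)-1-methylethyl on the double-bonded nitrogen gives a 5.3-fold lower number from compound 1 to compound 4 (0.73 log units; beyond the scatter) in this assay. The group at this position therefore affects the result on its own, and a group with no hydrogen-bond donor or acceptor gives the stronger inhibitor.

Still open, going by these compounds, is how the mirror-image sec-butyl, a cyclopentyl group or an aminoethyl group would behave at this position. No available measurement shows why the number falls.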